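A few compounds are considered here, and "the series" means these few. Any claim that something is new, unique, unknown or untested is made for them only; others in the source may bear on it.

Measured so far in a functional assay on CHO-K1 cells for antagonist activity at C-X-C chemokine receptor type 3 (Homo sapiens), read by FLIPR and calcium flux; on this read-out lower numbers stand for stronger inhibition and higher numbers for weaker inhibition: compound 1 `CC1CN(S(=O)(=O)C[C@]23CC[C@H](CC2=O)C3(C)C)CCN1c1ccc(C(F)(F)F)cn1` gives 316 nM. Compound 2 `CC1(C)[C@@H]2CC[C@@]1(CS(=O)(=O)N1CCN(c3ccc(Br)cn3)CC1)C(=O)C2` gives 1580 nM. For compound 3 `CC1(C)[C@@H]2CC[C@@]1(CS(=O)(=O)N1CCN(c3ccccn3)CC1)C(=O)C2` the assay returns only a limit, > 31600 nM.

Compound 1 thus holds the lowest of the two numbers, with compound 2 beyond the scatter above it; the third value is a limit, (the limit of > 31600 nM in this assay, at which 1 of the 3 values shown sits). Within the data shown here, the one measured step, an at least 20-fold higher number from compound 2 to compound 3 (1.30 log units; beyond the scatter), concerns a halogen on an aromatic carbon and says nothing about the move to compound 4 `C[C@H]1CN(S(=O)(=O)C[C@]23CC[C@H](CC2=O)C3(C)C)CCN1c1ccc(C(F)(F)F)cn1`. That move is the two compounds have the same atoms and bonds; at least one stereo element is drawn with a configuration in one of them and without one in the other: 1 of 3 stereo elements differ; a stereocentre at a saturated ring carbon is drawn without a configuration in compound 1 and S in compound 4: the same atoms and bonds, with a stereocentre at a saturated ring carbon drawn without configuration in compound 1 and as S in compound 4. Among the measured compounds shown here, no measured step involves a stereo element, so no direction follows from these data. Compound 4 is therefore expected near 250 nM, between 80 nM and 1000 nM, meaning a 1.3-fold lower number from compound 1 to compound 4 (0.10 log units; within the scatter).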

Compound 4, half-maximal inhibitory concentration: 158 nM
Beside the measured number, compound 4's estimate is 1.6-fold (0.20 log units) above it, and the stated range covers the measured number.
By their numbers in this assay, from the lowest: compounds 4 and 1 (each within the scatter of the next); then compound 2. At a limit, above all of these: compound 3.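

In this assay, among these compounds, the step is a 2.0-fold lower number from compound 1 to compound 4 (0.30 log units; within the scatter), so defining the saturated ring carbon as S gives a number within the scatter of the one for compound 1. Among the compounds shown here, this is the first measured step at a stereo element, yet it cannot be read as an effect of configuration alone, because only one partner has that carbon defined: the fact that one of compounds 1 and 4 is drawn with a defined configuration and the other without, at the place where they differ. The compounds shown leave open how the opposite configuration at that carbon would read. They also leave open how a nitrile or a methoxy group would compare with trifluoromethyl on this scaffold.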